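The source may report more compounds than this note shows. Statements on the series, on what has been measured and on what is new or still open speak of the compounds shown alone.

For the measured compounds named here, in a functional assay on CNE-2 cells (Homo sapiens) for inhibition, read by MTT assay, with a stated time of 72 h (on this read-out higher numbers stand for weaker inhibition and lower numbers for stronger inhibition), compound 1 (`CNC(=O)CCCCCCCn1nc(-c2cnc3[nH]ccc3c2)c2c(N)ncnc21`) gives 8990 nM as the only true number so far. Compound 2 (`Nc1nc2cc(-c3nn(CCC(=O)NO)c4ncnc(N)c34)ccc2o1`) reads > 150000 nM and that entry is a limit of the assay, not a number. Compound 3 (`Nc1ncnc2c1c(-c1cnc3[nH]ccc3c1)nn2CCC(=O)NO`) has yet to be measured. Against compound 1 it carries the change hydroxycarbamoyl in place of 5-(methylcarbamoyl)pentyl on a saturated chain carbon, two bonds along the chain from an aromatic nitrogen as counted, with hydroxycarbamoyl in place of 5-(methylcarbamoyl)pentyl on a saturated chain carbon, two bonds along the chain from an aromatic nitrogen. Going by the values given here, no measured pair shows a step of this kind, so its size in this assay remains a matter of expectation. That expectation leans on compound 2, whose > 150000 nM is again only a limit. The estimated move is a 3.9-fold higher number from compound 1 to compound 3 (0.59 log units; beyond the scatter) toward weaker inhibition and beyond the scatter, with wide uncertainty. Compound 3 is expected at 35000 nM within an estimated range of 7000 nM to 150000 nM for now.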

Compound 3, half-maximal inhibitory concentration: > 150000 nM
Compound 3 gave a limit, no number; the forecaster's own chance of this, stated with the estimate: 25%; middle value at least 4.2-fold (0.63 log units) from the limit.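

For the compounds shown here, with hydroxycarbamoyl in place of 5-(methylcarbamoyl)pentyl on a saturated chain carbon, two bonds along the chain from an aromatic nitrogen, this assay gives the first readable step at this position: an at least 16-fold higher number from compound 1 to compound 3 (1.22 log units; beyond the scatter). Compound 3 reads > 150000 nM, which is a limit of the assay and not a number, so the step has a floor but no measured size. Its true size cannot be read because the values stop at this limit: the limit of > 150000 nM in this assay, at which 2 of the 3 values shown sit.

Chain length and end group change together in this step, and the compounds shown do not separate the two. Also open, on these data alone, is how hydroxycarbamoyl on a longer chain, or a carboxylic acid or an amine at the end of the short chain, would read in this assay.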